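A few compounds are considered here, and "the series" means these few. Any claim that something is new, unique, unknown or untested is made for them only; others in the source may bear on it.

Going by the values given here, compound 1 `COc1cc(-c2cc(C(=O)/C=C/c3ccccc3)nc3cc(-c4ccccc4)nn23)cc(OC)c1OC` is one of only two compounds measured in an ADME assay on HEK293 cells (Homo sapiens) for antiproliferative activity, read by MTT assay, with a stated time of 24 h; on this read-out lower numbers stand for stronger inhibition and higher numbers for weaker inhibition; in this assay compound 1 gives 44800 nM. Compound 2 `COc1ccc(/C=C/C(=O)c2cc(-c3cc(OC)c(OC)c(OC)c3)n3nc(-c4ccccc4)cc3n2)cc1OC` differs from it in one place, and in this assay compound 2 gives 41000 nM; the step of a 1.1-fold lower number from compound 1 to compound 2 (0.04 log units; within the scatter) lies within the scatter, so the two numbers stand together and compound 1 is not set apart by either. Compound 3 `COc1cc(-c2cc(/C=C/C(=O)c3ccc(Cl)cc3)nc3cc(-c4ccccc4)nn23)cc(OC)c1OC` has not been measured. It differs from compound 1 in that (2-((4-chlorophenyl)carbonyl)ethenyl in place of (2-phenylethenyl)carbonyl on an aromatic carbon). Among the compounds with values here, the one measured step, from compound 1 to compound 2, changed the aryl at the end of the chain and not the order of carbonyl and ethenyl, and it was small, so it bears only loosely on this change; no measured step reports the reversed chain or the chlorine. The expected step of a 1.1-fold lower number from compound 1 to compound 3 (0.05 log units; within the scatter) is therefore modest, with no direction asserted beyond the scatter. Compound 3 is estimated at 40000 nM, with a range from 15000 nM to 110000 nM.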

Compound 3, half-maximal inhibitory concentration: >= 100000 nM
Compound 3: only a limit was reported; the forecaster's own chance of this, stated with the estimate: 10%; at least 2.5-fold (0.39 log units) between middle value and limit.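

Unlike the step from compound 1 to compound 2, which stayed within the scatter, the change on this aromatic carbon gives an at least 2.2-fold higher number from compound 1 to compound 3 (0.34 log units; beyond the scatter) in this assay, so the chain at this position can move the number towards weaker inhibition. The step swaps (2-phenylethenyl)carbonyl for 2-((4-chlorophenyl)carbonyl)ethenyl, so the reversed order of carbonyl and ethenyl and the chlorine enter together, and the shift cannot be assigned to either alone. The value of compound 3 is a limit of the assay and not a number: the limit of >= 100000 nM in this assay, at which 1 of the 3 values shown sits.

The compounds shown leave open whether the reversed chain without the chlorine would differ from compound 1, and what the true value of compound 3 is. Also open, on these data alone, is what an amine or a carboxylic acid in place of the chlorine would give.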